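The compounds below may be only part of what the source reports. "The series", "measured", "known", "first", "only" and "open" are said of these compounds alone.

Values in a functional assay on CCRF-CEM cells (Homo sapiens) for antiproliferative activity, read by sulforhodamine B assay, with a stated time of 48 h; a higher number here means a weaker inhibitor, a lower number a stronger inhibitor:
- compound 1 `O=C1NCCN1c1ccc(S(=O)(=O)Nc2ccc3[nH]ccc3c2)cc1`: 410 nM
- compound 2 `O=C1NCCN1c1ccc(S(=O)(=O)Nc2cccc(Br)c2)cc1`: 110 nM
- compound 3 `Cc1cc(C)cc(NS(=O)(=O)c2ccc(N3CCNC3=O)cc2)c1`: 170 nM

Compound 3, at 170 nM, lies within the scatter of compound 2, and compound 1 gives a higher number, beyond the scatter of compound 3.

Next is compound 4 `O=C1NCCN1c1ccc(S(=O)(=O)Nc2cccc(Cl)c2)cc1`, with 3-chlorophenyl in place of 3,5-dimethylphenyl on a sulfonamide nitrogen.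

Among the compounds with values here, one measured step bears on this change. Exchanging 3-bromophenyl for 3,5-dimethylphenyl gave a 1.5-fold higher number from compound 2 to compound 3 (0.19 log units; within the scatter), so no step beyond the scatter is expected in this assay, with a slight lean towards the value of compound 2.

The estimated step is a 1.4-fold lower number from compound 3 to compound 4 (0.15 log units; within the scatter).

Compound 4 is expected at 120 nM, with an estimated range of 60 nM to 240 nM.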

Compound 4, half-maximal inhibitory concentration: 77 nM
Estimate against measurement, compound 4: 1.6-fold (0.19 log units) above; the measured number falls inside the stated range.
By their numbers in this assay, from the lowest: compounds 4, 2 and 3 (each within the scatter of the next, the first and the last beyond it); then compound 1.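

In this assay, within the data shown here, 3-chlorophenyl in place of 3,5-dimethylphenyl on the sulfonamide nitrogen gives the first step beyond the scatter, though a modest one (a 2.2-fold lower number from compound 3 to compound 4 (0.34 log units; beyond the scatter)). Chloro in place of bromo on an aromatic carbon stays within the scatter (a 1.4-fold lower number from compound 2 to compound 4 (0.15 log units; within the scatter)), so these two halogens are not separated in this assay. No measurement at hand accounts for either step.

Open: whether fluoro would read like chloro and bromo in this assay. On these data alone, also open: how an aryl group on the sulfonamide nitrogen carrying an amine or a carboxylic acid would compare.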